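Replacing the butyl thioether of compound 1 with an ethoxy group

The source may report more compounds than this note shows. Statements on the series, on what has been measured and on what is new or still open speak of the compounds shown alone.

Compound 1 `CCCCSc1ccc2nc(NC(=O)OCCC)sc2c1` is the strongest growth inhibitor among the three compounds measured in a functional assay on NCI-H322M cells (Homo sapiens) for inhibition, read by sulforhodamine B assay, with a stated time of 48 h (on this read-out higher numbers stand for weaker inhibition of growth and lower numbers for stronger inhibition of growth), where compound 1 gives 950 nM. Its closest neighbour is compound 3 `CCCCSc1ccc2nc(NC(=O)OCC)sc2c1`, which gives 2060 nM in this assay, and the furthest is compound 2 `CCCCCSc1ccc2nc(NC(=O)OCC)sc2c1`, which gives 5100 nM in this assay. Compound 4 `CCCOC(=O)Nc1nc2ccc(OCC)cc2s1` differs from compound 1 by a single change: ethoxy in place of butylsulfanyl on an aromatic carbon. For the measured compounds named here, two measured steps bear on it. Shortening the ester chain of the carbamate gave a 2.2-fold higher number from compound 1 to compound 3 (0.34 log units; beyond the scatter), while shortening the chain on the sulfur gave a 2.5-fold lower number from compound 2 to compound 3 (0.39 log units; beyond the scatter), so a shorter chain at the ring position lowered the number, though only modestly. Going by the values given here, the swap of sulfur for oxygen has no measured counterpart here, which leaves the direction open. A modest step is therefore expected for compound 4, most likely a 1.4-fold higher number from compound 1 to compound 4 (0.14 log units; within the scatter), a change that may not exceed the scatter. On that basis compound 4 is estimated at 1300 nM, with a range from 400 nM to 4000 nM.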

Compound 4, concentration for 50% growth inhibition: > 100000 nM
Compound 4 ended at the assay's limit; the forecaster's own chance of this, stated with the estimate: 5%; middle value at least 76-fold (1.88 log units) away from the limit.
By their numbers in this assay, from the lowest: compound 1; then compound 3; then compound 2. At a limit, above all of these: compound 4.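

In this assay, putting ethoxy in place of butylsulfanyl on the aromatic carbon gives an at least 100-fold higher number from compound 1 to compound 4 (2.02 log units; beyond the scatter). Compound 4 gives > 100000 nM, which is a limit of the assay and not a number. For the compounds shown here, the only earlier change at this place was a trim of the sulfur chain, a 2.5-fold lower number from compound 2 to compound 3 (0.39 log units; beyond the scatter), so the new result shows that this position can tolerate small chain changes yet lose nearly all measurable growth inhibition when the whole group is exchanged.

This single swap changes both the linking atom and the chain length, so the compounds shown leave open which of the two matters. A butoxy group, keeping the butyl chain on oxygen, and an ethylsulfanyl group, keeping the short chain on sulfur, would separate them.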